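The compounds below may be only part of what the source reports. "The series", "measured", "known", "first", "only" and "open" are said of these compounds alone.

Going by the values given here, in a functional assay on Raji cells (Homo sapiens) for cytotoxicity, with a stated time of 72 h (a lower number here means that less compound is needed, a higher number that more compound is needed for the effect), compound 3 (`COc1ccc(/C=C/[C@@](C)(/C=C/c2ccc(O)c(C=O)c2)CCC=C(C)C)cc1`) gives 13000 nM as the only actual number so far. Compound 1 (`C=C[C@@](C)(/C=C/c1ccc(O)cc1)CCC(O)C(C)(C)O`) gives > 26000 nM as a limit of the assay. Compound 2 (`C=C[C@@](C)(/C=C/c1ccc(O)cc1)CC/C=C(C)/C=N/N`) gives > 26000 nM as a limit too. Both rest on the limit of > 26000 nM in this assay, at which 2 of the 3 values shown sit, and not on numbers. Compound 4 (`CCOC(=O)/C=C/c1cc(/C=C/[C@](C)(/C=C/c2ccc(OC)cc2)CCC=C(C)C)ccc1O`) carries 2-(ethoxycarbonyl)ethenyl in place of formyl on an aromatic carbon. Among the compounds with values here, the only measured step, a step that the two limits leave unreadable from compound 1 to compound 2, has no readable size and does not touch this position. The estimate therefore starts from compound 3 at 13000 nM and expects no change beyond the scatter in this assay in either direction. The expected step is a 1.1-fold lower number from compound 3 to compound 4 (0.03 log units; within the scatter) by this estimate. Compound 4 is expected at 12000 nM with an estimated range of 5000 nM to 26000 nM in this assay.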

Compound 4, half-maximal effective concentration: > 26000 nM
Compound 4 gave a limit, no number; the forecaster's own chance of this, stated with the estimate: 25%; middle value at least 2.1-fold (0.33 log units) from the limit.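

Going by these compounds alone, the change from formyl to 2-(ethoxycarbonyl)ethenyl on this aromatic carbon, ortho to a hydroxy group, is an at least 2.0-fold higher number from compound 3 to compound 4 (0.30 log units; that floor lies within the scatter) in this assay, the first step at this position that can be read at all. Going by these compounds, compound 4 gives a limit of the assay, so the step has only a floor and its true size stays unknown: the limit of > 26000 nM in this assay, at which 3 of the 4 values shown sit. Within the data shown here, compound 3 remains the only compound with an actual number. On these data alone, whether an amine or a carboxylic acid on this aromatic carbon would give a number remains open.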